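The compounds below may be only part of what the source reports. "The series", "measured", "known", "first", "only" and "open" are said of these compounds alone.

Among the compounds with values here, in a functional assay on A549 cells (Homo sapiens) for inhibition, read by MTT assay, with a stated time of 48 h (on this read-out lower numbers stand for stronger inhibition and higher numbers for weaker inhibition), compound 1 `COc1ccc(C/N=C2\NC(=O)/C(=C3\CCNC(=O)c4[nH]ccc43)S2)cc1` gives 18300 nM, the only true number available so far. Compound 2 `O=C1N/C(=N\Cc2ccccc2Cl)S/C1=C1/CCNC(=O)c2[nH]ccc21` reads > 100000 nM, and this is a limit of the assay, not a number. The change between these two is an at least 5.4-fold higher number from compound 1 to compound 2 (0.73 log units; beyond the scatter), which leaves compound 1 as the more active of the pair.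

Compound 3 `CC(C)(C)c1ccc(C/N=C2\NC(=O)/C(=C3\CCNC(=O)c4[nH]ccc43)S2)cc1` keeps the core of compound 1 and alters a single group, with tert-butyl in place of methoxy on an aromatic carbon. Within the data shown here, only one measured step bears on this change. It also replaces the 4-methoxyphenyl group of compound 1, and compound 2 moved upward in that step, an at least 5.4-fold higher number from compound 1 to compound 2 (0.73 log units; beyond the scatter). A single case sets no rule, and the group that enters compound 3 is a different one, so only a moderate rise in this assay is expected, with no change beyond the scatter also possible. The estimate for this change is a 1.9-fold higher number from compound 1 to compound 3 (0.28 log units; within the scatter). For compound 3, the expected value is 35000 nM, within an estimated range of 9000 nM to 90000 nM.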

Compound 3, half-maximal inhibitory concentration: 43900 nM
Beside the measured number, compound 3's estimate is 1.3-fold (0.10 log units) below it; the range from low to high includes it.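

Compound 2 left the size of its step unknown, since it changed the ring's substituent and its place together and its reading is only a limit of the assay: the limit of > 100000 nM in this assay, at which 1 of the 3 values shown sits.

Within the data shown here, compound 3 gives the first step with a true number at both ends, and it alters only the group on an aromatic carbon, para to a large group: in this assay, the change gives a 2.4-fold higher number from compound 1 to compound 3 (0.38 log units; beyond the scatter). This modest step, beyond the scatter, shows that this position responds to the group it carries, yet a tert-butyl of 4 heavy atoms and no hydrogen-bond acceptor still leaves a measurable number rather than a limit.

Methoxy and tert-butyl differ in both heavy-atom count and hydrogen-bond acceptors, so this single step cannot tell which of these differences matters, or whether either does. On these data alone, whether an amine, a carboxylic acid or a longer chain at this same position would give a lower number than compound 1 also stays open, and so does whether any such change would carry over to other cell lines.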